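Shortening the chain substituent: compound 3 to compound 4

The source may hold more compounds than are shown below. What is called first, only, known or untested is meant among the compounds shown, and "the series" means these compounds.

Measured compounds:
- compound 1 `CC(C(=O)N1CCN(c2ccc(Cl)cc2)CC1)N1C(=O)CCC1=O`, in a functional assay on the whole organism (strain Swiss) with Mus musculus as the target, in the maximal electroshock model, with a stated time of 0.25 h, at a dose of 100 mg/kg by the intraperitoneal route (on this read-out lower numbers stand for a weaker effect and higher numbers for a stronger effect at the one dose given), compound 1 gives 50%
- compound 2 `CC(C(=O)N1CCN(c2cccc(C(F)(F)F)c2)CC1)N1C(=O)CCC1=O`, in this assay compound 2 gives 50%
- compound 3 `CCC(C(=O)N1CCN(c2cccc(Cl)c2)CC1)N1C(=O)CCC1=O`, in this assay compound 3 gives 50%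

All three measured compounds sit at the same reading in this assay at the digits shown. Compound 3 stands level with compound 1 and with compound 2, the gaps to both lying within the usual scatter of this kind of measurement, so no ordering among the three can be drawn from these numbers. Among the compounds with values here, no single-point step between measured compounds is available in this set, and no trend with the substituent on the chain carbon or on the aryl ring can be claimed from it.

Compound 4 `CC(C(=O)N1CCN(c2cccc(Cl)c2)CC1)N1C(=O)CCC1=O` is the next compound to be measured. The change from compound 3 is hydrogen in place of methyl on a saturated chain carbon, two bonds along the chain from an amide-type nitrogen in a ring and a carbonyl carbon. Since compounds 1, 2 and 3 give the same reading despite differing at the aryl ring and at this chain carbon, the step from compound 3 to compound 4 in this assay is expected to be none beyond the scatter, no change at the digits printed from compound 3 to compound 4 (within the scatter). Compound 4 is therefore estimated at 50%, within a range from 25% to 75%.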

Compound 4, a percentage reported as activity, at one dose (the size of the read-out at that dose, not a potency): 50%
For compound 4 middle estimate and measured number coincide at the digits printed; the measured number falls inside the stated range.
By their numbers in this assay, from the lowest: compounds 1, 2, 3 and 4 (each within the scatter of the next).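

In this assay, within the data shown here, hydrogen in place of methyl on the saturated chain carbon gives no change at the digits printed from compound 3 to compound 4 (within the scatter) and so provides a direct single-place reading at this position, which the earlier compounds lacked. The aryl ring now has direct readings too: chloro in place of trifluoromethyl on an aromatic carbon gives no change at the digits printed from compound 2 to compound 4 (within the scatter) in this read-out, and 3-chlorophenyl in place of 4-chlorophenyl on an amine nitrogen in a ring gives no change at the digits printed from compound 1 to compound 4 (within the scatter) as well. No measured data bear on the reason for these readings.

Going by these compounds, whether a longer chain than ethyl, an amine or a carboxylic acid on this chain carbon would move the reading stays open. On these data alone, it is also open whether an unsubstituted phenyl or a methoxy group on the aryl ring would separate from these compounds at the single dose given.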